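The compounds below may be only part of what the source reports. "The series", "measured", "known", "first", "only" and "open" are said of these compounds alone.

Compound 1 `C=CC[C@@]12C[C@@H](C(=O)OC)N3[C@@H]1N(C(=N)C31CCCCC1)c1ccccc12`: 25200 nM
Compound 2 `COC(=O)[C@@H]1C[C@@]2(CC=C(C)C)c3ccccc3N3C(=N)C(C)(C)N1[C@H]32`: 28300 nM
Compound 3 `COC(=O)[C@@H]1C[C@@]2(CC=C(C)C)c3ccccc3N3C(=N)[C@H](Cc4ccccc4)N1[C@H]32`: 24100 nM

In a functional assay on HT-29 cells (Homo sapiens) for cytotoxicity, read by sulforhodamine B assay, with a stated time of 48 h (a lower number here means that less compound is tolerated, a higher number that more compound is tolerated), compound 3 gives 24100 nM, the lowest of the three numbers, yet its gaps to compound 1 and to compound 2 both fall within the usual scatter, so no order among the three can be claimed. Compound 4 `COC(=O)[C@@H]1C[C@@]2(CC=C(C)C)c3ccccc3N3C(=N)[C@H](C(C)(C)C)N1[C@H]32` differs from compound 3 by tert-butyl in place of benzyl on a saturated ring carbon. Among the compounds with values here, no step between measured compounds exists to calibrate this change; what the data show is that three differently substituted members all land within the scatter of one another. Compound 4 is therefore expected to give 26000 nM, estimated to lie between 11000 nM and 60000 nM. This amounts to an expected step of a 1.1-fold higher number from compound 3 to compound 4 (0.03 log units; within the scatter), none beyond the scatter.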

Compound 4, concentration lethal to 50% of the cells: > 100000 nM
Compound 4: only a limit was reported; the forecaster's own chance of this, stated with the estimate: 10%; middle value at least 3.8-fold (0.58 log units) away from the limit.
By their numbers in this assay, from the lowest: compounds 3, 1 and 2 (each within the scatter of the next). At a limit, above all of these: compound 4.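

Placed on the saturated ring carbon of the five-membered ring, tert-butyl in place of benzyl gives an at least 4.1-fold higher number from compound 3 to compound 4 (0.61 log units; beyond the scatter) in this assay. Within the data shown here, this is the first step that lies beyond the scatter, so the group at this position can matter in this assay. Compound 4 is reported only as a limit, so the full size of the step stays unknown: the limit of > 100000 nM in this assay, at which 1 of the 4 values shown sits.

The compounds shown leave open whether losing the aromatic ring of benzyl or gaining tert-butyl accounts for the step. They also leave open how an amine, a carboxylic acid or a longer chain would read at this position.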